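The source may report more compounds than this note shows. Statements on the series, on what has been measured and on what is new or still open speak of the compounds shown alone.

In a functional assay on Bel7402/5-FU cells (Homo sapiens) for antiproliferative activity, read by MTT assay, with a stated time of 72 h (on this read-out lower numbers stand for stronger inhibition and higher numbers for weaker inhibition), compound 1 `C=C1C(=O)O[C@H]2[C@H]1CC/C(COC(=O)Cn1cc(F)c(=O)[nH]c1=O)=C\CC[C@@]1(C)O[C@@H]21` gives > 20000 nM, and this is a limit of the assay, not a number. Placing a benzyl group on the aromatic nitrogen gives compounds with measurable values. With 2-fluorobenzyl, compound 2 `C=C1C(=O)O[C@H]2[C@H]1CC/C(COC(=O)Cn1cc(F)c(=O)n(Cc3ccccc3F)c1=O)=C\CC[C@@]1(C)O[C@@H]21` reaches 3830 nM, and with 2,6-difluorobenzyl, compound 3 `C=C1C(=O)O[C@H]2[C@H]1CC/C(COC(=O)Cn1cc(F)c(=O)n(Cc3c(F)cccc3F)c1=O)=C\CC[C@@]1(C)O[C@@H]21` reaches 4980 nM. These changes appear as an at least 5.2-fold lower number from compound 1 to compound 2 (0.71 log units; beyond the scatter) and an at least 4.0-fold lower number from compound 1 to compound 3 (0.60 log units; beyond the scatter), both beyond the scatter. Compound 3 therefore stands level with compound 2, since a 1.3-fold higher number from compound 2 to compound 3 (0.11 log units; within the scatter) lies within the scatter.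

Compound 4 `C=C1C(=O)O[C@H]2[C@H]1CC/C(COC(=O)Cn1cc(F)c(=O)n(Cc3cc(F)ccc3F)c1=O)=C\CC[C@@]1(C)O[C@@H]21` has the same atoms as compound 3, joined differently: 2,5-difluorophenyl in place of 2,6-difluorophenyl on a saturated chain carbon bound to an aromatic nitrogen. In words, 2,5-difluorophenyl sits in place of 2,6-difluorophenyl on a saturated chain carbon bound to an aromatic nitrogen. The benzyl group behind the large steps from compound 1 is kept, so those steps bear on this change only indirectly. The closest guide is the change in fluorines on the benzyl ring from compound 2 to compound 3, a 1.3-fold higher number from compound 2 to compound 3 (0.11 log units; within the scatter), which stayed within the scatter. No shift beyond the scatter is therefore expected in this assay, and the estimated step is a 1.2-fold lower number from compound 3 to compound 4 (0.06 log units; within the scatter). The estimated value for compound 4 is 4300 nM, with an expected range from 2000 nM to 9500 nM.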

Compound 4, half-maximal inhibitory concentration: 4610 nM
For compound 4 the middle estimate is 1.1-fold (0.03 log units) below the measured one; the range from low to high includes it.
By their numbers in this assay, from the lowest: compounds 2, 4 and 3 (each within the scatter of the next). At a limit, above all of these: compound 1.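

In this assay, putting 2,5-difluorophenyl in place of 2,6-difluorophenyl gives a 1.1-fold lower number from compound 3 to compound 4 (0.03 log units; within the scatter), and the comparison with the 2-fluorobenzyl compound gives a 1.2-fold higher number from compound 2 to compound 4 (0.08 log units; within the scatter), so neither the arrangement of the two fluorines tested here nor the extra fluorine on the ring produces a difference that can be told apart from ordinary measurement noise. The large gain from placing a benzyl group on the aromatic nitrogen now holds for a third fluorinated benzyl group, with an at least 4.3-fold lower number from compound 1 to compound 4 (0.63 log units; beyond the scatter). Compound 1 is held at a limit and not a number, so this step gives only a lower bound on the gain: the limit of > 20000 nM in this assay, at which 1 of the 4 values shown sits.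

All the benzyl rings shown carry fluorine alone, and their values lie within the scatter of one another, so it remains open how far this part of the molecule can be changed before the number moves. A plain unsubstituted benzyl, a chloro or methoxy group on the ring, or a longer chain between the aromatic nitrogen and the ring would each test this more strongly.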